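Aryl exchange on the shared core: compound 2 to compound 3

The source may hold more compounds than are shown below. What is called first, only, known or untested is meant among the compounds shown, and "the series" means these compounds.

In a functional assay on MCF7 cells (Homo sapiens) for antiproliferative activity, read by MTT assay, with stated times of 24 h and 72 h (a higher number here means a weaker inhibitor, a lower number a stronger inhibitor), compound 1 (`COc1cc(N2C(=O)[C@@H](Oc3ccccc3)[C@H]2c2ccc(N(C)C)cc2)cc(OC)c1OC`) gives 31000 nM as its reading, and compound 2 (`COc1cc(N2C(=O)[C@@H](Oc3ccccc3)[C@H]2c2cccc([N+](=O)[O-])c2)cc(OC)c1OC`) gives 30000 nM as its reading, which places compound 2 level with compound 1 within the scatter. Compound 3 (`COc1cc([C@@H]2[C@H](Oc3ccccc3)C(=O)N2c2cc(OC)c(OC)c(OC)c2)ccc1O`) is still unmeasured. It carries 4-hydroxy-3-methoxyphenyl in place of 3-nitrophenyl on a saturated ring carbon. Within the data shown here, the only measured step bearing on this exchange is a 1.0-fold lower number from compound 1 to compound 2 (0.01 log units; within the scatter) on replacing 4-(dimethylamino)phenyl with 3-nitrophenyl at that ring carbon, and it stays within the scatter. One step is thin guidance, and the entering group matches neither measured group, so a modest move toward a lower number is expected in this assay with wide uncertainty. The estimated step is a 3.0-fold lower number from compound 2 to compound 3 (0.48 log units; beyond the scatter) on this reasoning. Compound 3 is estimated at 10000 nM within a range of 800 nM to 35000 nM for now.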

Compound 3, half-maximal inhibitory concentration: 32000 nM
Compound 3: middle estimate off by 3.2-fold (0.51 log units), on the low side; low and high end bracket the measured number.
By their numbers in this assay, from the lowest: compounds 2, 1 and 3 (each within the scatter of the next).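

In this assay, 4-hydroxy-3-methoxyphenyl in place of 3-nitrophenyl on the saturated ring carbon gives a 1.1-fold higher number from compound 2 to compound 3 (0.03 log units; within the scatter), and in place of 4-(dimethylamino)phenyl it gives a 1.0-fold higher number from compound 1 to compound 3 (0.01 log units; within the scatter). Unlike 3-nitrophenyl, the entering group has a hydrogen-bond donor, yet compound 3 stays level with compound 2, so the three aryl groups shown at this ring carbon now read alike across compounds 1, 2 and 3. Nothing measured accounts for this agreement between the readings.

The compounds shown leave open whether a group of another kind on this ring carbon, such as a carboxylic acid or a saturated chain ending in an amine, would separate from these readings. Also open, as far as these compounds go, is what an amine would do in place of the phenoxy group on the neighbouring ring atom that bears it.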